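The source may hold more compounds than are shown below. What is called first, only, known or untested is meant among the compounds shown, and "the series" means these compounds.

Measured compounds:
- compound 1 `COc1ccc(NC(=O)COc2cc(C)nc3ccc(OC)cc23)cc1`, in a toxicity assay on HepG2 cells (Homo sapiens) for inhibition, read by CellTiter-Glo, with a stated time of 48 h (on this read-out higher numbers stand for weaker inhibition and lower numbers for stronger inhibition), gives > 100000 nM, which is a limit of the assay and not a number.
- compound 2 `COc1ccc2nc(C)cc(OCC(=O)Nc3cc(OC)c(OC)c(OC)c3)c2c1`, in this assay gives > 100000 nM, again a limit and not a number.

For the measured compounds named here, compound 1 therefore stands at the upper end of what this assay reports: the limit of > 100000 nM in this assay, at which 2 of the 2 values shown sit, so every value shown so far is a limit, and no step between measured compounds can be drawn. Compound 1 and compound 2 differ only in the amide substituent, and both sit at the same limit, which is all their two values show.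

Compound 3 `COc1ccc2nc(C)cc(OCC(=O)Nc3nccs3)c2c1` remains to be measured. Its change from compound 1 is 1,3-thiazol-2-yl in place of 4-methoxyphenyl on an amide-type nitrogen. Going by the values given here, with no measured step to lean on, the expected step in this assay from compound 1 to compound 3 is a number no higher from compound 1 to compound 3 (the limit leaves the size open), which is none beyond the scatter; the likeliest outcome is that compound 3 is also reported as a limit. The estimate for compound 3 in this assay is 100000 nM, with a range from 30000 nM to 300000 nM.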

Compound 3, half-maximal inhibitory concentration: > 100000 nM
Compound 3: no number, only a limit (the forecaster's own chance of this, stated with the estimate: 75%); the middle value lies on the limit itself.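

No step can be read from compound 1 to compound 3 in this assay, because the values of both compounds are limits and not numbers: the limit of > 100000 nM in this assay, at which 3 of the 3 values shown sit.

The compounds shown leave open whether any amide substituent on the shared core gives a measurable value in this assay, and how 4-methoxyphenyl and 1,3-thiazol-2-yl would rank.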